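The source may report more compounds than this note shows. Statements on the series, on what has been measured and on what is new or still open speak of the compounds shown alone.

The study turns on a shared core, seen first in compound 1 as `O=[N+]([O-])c1ccc(CN(Cc2ccc(Cl)cc2)CC2CCN(Cc3ccccc3)C2)s1` and carried through compound 2 as `CC(=O)N1CCC(CN(Cc2ccc(Cl)cc2)Cc2ccc([N+](=O)[O-])s2)C1` and compound 3 as `CCCCNC(=O)N1CCC(CN(Cc2ccc(Cl)cc2)Cc2ccc([N+](=O)[O-])s2)C1`. For the measured compounds named here, for compound 1 the entry in a functional assay on HEK293 cells for agonist activity at nuclear receptor subfamily 1 group D member 1 (Homo sapiens), read by a luciferase reporter, with a stated time of 24 h (on this read-out lower numbers stand for an effect already at smaller amounts and higher numbers for an effect only at larger amounts of compound), reads "not determined" (no result reported), so compound 2 is the only compound here that carries a number. In this assay, going by the values given here, compound 2 gives 1600 nM, and this single value is the whole foothold for what follows; with no second measured compound there is no measured step to lean on.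

Compound 3 departs from compound 2 in one place: butylamino in place of methyl on a carbonyl carbon. Cut one bond further out, the change reads acetyl to butylcarbamoyl. Among the compounds with values here, nothing measured here tells how such a change plays out in this assay, so the expectation rests on the single number of compound 2 and the counted difference alone. The step of a 1.8-fold lower number from compound 2 to compound 3 (0.25 log units; within the scatter) is expected to be modest, toward lower numbers, and not far beyond the usual scatter. Compound 3 is therefore estimated at 900 nM in this assay, with a range from 300 nM to 2500 nM.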

Compound 3, half-maximal effective concentration: 670 nM
The estimate for compound 3 lay 1.3-fold (0.13 log units) above the measured number, within the range that was stated.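

With this result the position gains its first measured step: on a carbonyl carbon whose other neighbour is an amide-type nitrogen in a ring, butylamino in place of methyl gives (a 2.4-fold lower number from compound 2 to compound 3 (0.38 log units; beyond the scatter)) in (this assay), a modest shift that lies beyond the scatter. The earlier compounds shown here could not show this, since compound 2 alone carried a number, and the step now shows that this position tolerates a change from one heavy atom to five, with one hydrogen-bond donor entering, and that the number moves toward lower values. No measurement at hand explains this step.

The single change brings in a nitrogen and a four-carbon chain together, so the compounds shown do not separate the two, and methylamino, a plain pentanoyl group or a longer chain such as hexylamino on the same carbonyl carbon would be needed to tell them apart. Because compound 1 carries no number, they also leave open how a group without the carbonyl at this ring nitrogen compares, as they do for a carboxylic acid or a free amine at the end of the butyl chain.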